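Moving a Methoxy Group Around the Benzyl Ring

The compounds below may be only part of what the source reports. "The series", "measured", "known", "first", "only" and "open" are said of these compounds alone.

Compound 2 `COc1cc(CNC(=O)c2cc3nc(C)c([C@H](OC(C)(C)C)C(=O)O)c(-c4cc(F)c5c(c4C)CCCO5)n3n2)ccc1F` has been tested in an ADME assay on MT2 cells (Homo sapiens) for cytotoxicity; on this read-out lower numbers stand for higher toxicity in this test and higher numbers for lower toxicity in this test. In this assay compound 2 gives > 20000 nM, which is a limit of the assay rather than a measured number. Its nearest measured neighbour, compound 1 `Cc1cc(CNC(=O)c2cc3nc(C)c([C@H](OC(C)(C)C)C(=O)O)c(-c4cc(F)c5c(c4C)CCCO5)n3n2)ccc1F`, differs from it only by a methoxy in place of methyl on an aromatic carbon. In this assay compound 1 gives > 40000 nM, again a limit. The step that the two limits leave unreadable from compound 1 to compound 2 cannot be sized because the limit of > 20000 nM in this assay, at which 1 of the 2 values shown sits, and the limit of > 40000 nM in this assay, at which 1 of the 2 values shown sits, are where the two readings sit, so no real direction or size can be read from it.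

Compound 3 `COc1cc(F)ccc1CNC(=O)c1cc2nc(C)c([C@H](OC(C)(C)C)C(=O)O)c(-c3cc(F)c4c(c3C)CCCO4)n2n1` has the same atoms as compound 2, joined differently: 4-fluoro-2-methoxyphenyl in place of 4-fluoro-3-methoxyphenyl on a saturated chain carbon bound to an amide-type nitrogen. Within the data shown here, no measured step bears directly on this rearrangement, and the single step that exists tells nothing of size. With both known values resting at limits, the expectation is that compound 3 also stays at or past the limit, so the step that the limit leaves unreadable from compound 2 to compound 3 is expected to be essentially flat. Compound 3 is estimated at 40000 nM, within 15000 nM to 100000 nM.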

Compound 3, half-maximal cytotoxic concentration: > 40000 nM
Compound 3 gave a limit, no number; the forecaster's own chance of this, stated with the estimate: 85%; the middle value lies on the limit itself.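

In this assay compound 3 gives > 40000 nM, which is a limit and not a number. Among these compounds, with compound 1, compound 2 and compound 3 all resting at limits, no step among them can be read. The compounds shown leave open at what concentration any of the three becomes toxic, and whether swapping or moving these benzyl ring groups changes that concentration.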